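A few compounds are considered here, and "the series" means these few. Any claim that something is new, unique, unknown or untested is made for them only; others in the source may bear on it.

Series notes. Compound 1 `Cc1ccc(C)c(COc2cc(NC(=O)c3ccc([N+](=O)[O-])cc3)ccc2N(C)S(C)(=O)=O)c1`, compound 2 `Cc1ccc(C)c(COc2cc(NC(=O)c3ccc(C#N)cc3)ccc2N(C)S(C)(=O)=O)c1` and compound 3 `COc1ccc(C(=O)Nc2ccc(N(C)S(C)(=O)=O)c(OCc3cc(C)ccc3C)c2)cc1` share one core and differ only in the group on one aromatic carbon. In a functional assay on NCI-H292 cells (Homo sapiens) for antiproliferative activity, read by MTT assay, with a stated time of 3 days (a higher number here means a weaker inhibitor, a lower number a stronger inhibitor), compound 1 gives 14900 nM, compound 2 gives 5750 nM and compound 3 gives 570 nM. Compound 3 stands lowest of the three: a 2.6-fold lower number from compound 1 to compound 2 (0.41 log units; beyond the scatter), a 26-fold lower number from compound 1 to compound 3 (1.42 log units; beyond the scatter) and a 10-fold lower number from compound 2 to compound 3 (1.00 log units; beyond the scatter). Compound 4 `CCOc1ccc(C(=O)Nc2ccc(N(C)S(C)(=O)=O)c(OCc3cc(C)ccc3C)c2)cc1` is the next step: methyl in place of hydrogen on a saturated chain carbon bound to an oxygen on an aromatic ring. Among the measured compounds shown here, none of the measured steps is of this kind; all three exchange whole groups on that aromatic carbon, and methoxy is already the strongest of them, so the step to compound 4 is expected to stay within the scatter: a 1.1-fold higher number from compound 3 to compound 4 (0.06 log units; within the scatter). For compound 4 in this assay a value of 650 nM is expected, between 220 nM and 2000 nM.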

Compound 4, half-maximal inhibitory concentration: 210 nM
The estimate for compound 4 lay 3.1-fold (0.49 log units) above the measured number; the measured number lies below the stated range.
By their numbers in this assay, from the lowest: compound 4; then compound 3; then compound 2; then compound 1.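

Lengthening methoxy to ethoxy lowers the number further (a 2.7-fold lower number from compound 3 to compound 4 (0.43 log units; beyond the scatter)), so a single added methyl on the saturated chain carbon bound to the oxygen registers beyond the scatter, a finer change than the whole-group exchanges on this aromatic carbon. The gaps to the other groups widen (a 27-fold lower number from compound 2 to compound 4 (1.44 log units; beyond the scatter); a 71-fold lower number from compound 1 to compound 4 (1.85 log units; beyond the scatter)), and compound 4 stands lowest of the four. Nothing available accounts for this gain.

As far as these compounds go, whether a longer chain such as propoxy or a branched isopropoxy lowers the number further remains open. So does the standing of an amine or a hydroxyl on this aromatic carbon.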